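Notes on a Trifluoromethylcyclopentyl Amide Replacement

The source may hold more compounds than are shown below. What is called first, only, known or untested is meant among the compounds shown, and "the series" means these compounds.

Compound 1 `CC(C)(C)OC(=O)N1CCC(O[C@H]2CC[C@H](Oc3ccc(S(C)(=O)=O)cn3)CC2)CC1` and compound 2 `CC1(OC(=O)N2CCC(O[C@H]3CC[C@H](Oc4cnc(S(C)(=O)=O)cn4)CC3)CC2)CC1` share a core and both reach a full maximal response in a functional assay on isolated protein for agonist activity at Glucose-dependent insulinotropic receptor (Homo sapiens), read by HTRF and cAMP accumulation; a lower number here means a smaller maximal response, a higher number a larger maximal response: compound 1 gives 111%, and compound 2 gives 118%. The two values lie within the usual scatter of each other, so compound 2 is not set apart from compound 1. Compound 3 `CS(=O)(=O)c1cnc(O[C@H]2CC[C@H](OC3CCN(C(=O)C4(C(F)(F)F)CCCC4)CC3)CC2)cn1` is not yet measured. It differs from compound 2 as follows: a group of 9 heavy atoms (6 carbon, 3 fluorine; one five-membered non-aromatic ring of carbon only) in place of a group of 5 heavy atoms (4 carbon, 1 oxygen; one three-membered non-aromatic ring of carbon only), on a carbonyl carbon. For the measured compounds named here, with only two measured compounds and no step beyond the scatter between them, no direction can be drawn from the numbers. Compound 3 is expected to keep a full response, with the estimated step of a number 10 percentage points lower from compound 2 to compound 3 (within the scatter) remaining within the scatter. The estimate for compound 3 is 108%, between 85% and 130%.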

Compound 3, largest response reached (Emax), in percent of the reference or control that the assay uses: 95%
Estimate against measurement, compound 3: 13 percentage points above; the measured number falls inside the stated range.
By their numbers in this assay, from the lowest: compound 3; then compounds 1 and 2 (each within the scatter of the next).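

For the compounds shown here, on the carbonyl carbon whose other neighbour is the amide-type nitrogen in a ring, replacing (1-methylcyclopropyl)oxy with the trifluoromethylcyclopentyl group gives, in this assay, a number 23 percentage points lower from compound 2 to compound 3 (beyond the scatter), the only step here beyond the scatter. This position is therefore not indifferent to the group it carries, although compound 3 still reaches 95%. No measurement available bears on the origin of this step.

The change alters the ring, the fluorines and the linking oxygen at once, so their separate contributions remain unresolved. A 1-methylcyclopentyl group on the same carbonyl, or a (1-trifluoromethylcyclopropyl)oxy group, would help to separate them.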